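The source may report more compounds than this note shows. Statements on the series, on what has been measured and on what is new or still open speak of the compounds shown alone.

Three diaryl ureas built on one shared core have been tested in a functional assay on HT-29 cells (Homo sapiens) for inhibition, read by MTT assay, with a stated time of 120 h; a higher number here means a weaker inhibitor, a lower number a stronger inhibitor. Compound 1 `CNC(=O)/C(C)=C/c1ccc(NC(=O)Nc2ccc(Cl)c(C(F)(F)F)c2)cc1` sits at a limit of the assay, > 50000 nM. Compound 2 `CNC(=O)CCc1ccc(NC(=O)Nc2ccc(Cl)c(C(F)(F)F)c2)cc1` gives 20600 nM. Compound 3 `CC1CN(C(=O)CCc2ccc(NC(=O)Nc3ccc(Cl)c(C(F)(F)F)c3)cc2)CC(C)O1` is again at a limit, > 50000 nM. The cores of compound 1 and compound 2 differ in that compound 1 carries 2-(methylcarbamoyl)prop-1-en-1-yl in place of 2-(methylcarbamoyl)ethyl on an aromatic carbon, and the step of an at least 2.4-fold lower number from compound 1 to compound 2 (0.38 log units; beyond the scatter). From compound 2 to compound 3 the change is 2,6-dimethylmorpholin-4-yl in place of methylamino on a carbonyl carbon, which gave an at least 2.4-fold higher number from compound 2 to compound 3 (0.38 log units; beyond the scatter); the size is known only as a bound because of the limit of > 50000 nM in this assay, at which 2 of the 3 values shown sit.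

Compound 4 `C/C(=C\c1ccc(NC(=O)Nc2ccc(Cl)c(C(F)(F)F)c2)cc1)C(=O)N1CC(C)OC(C)C1` has not yet been measured. It differs from compound 1 by 2,6-dimethylmorpholin-4-yl in place of methylamino on a carbonyl carbon. The surroundings are not identical: in compound 4 the other neighbour of the carbonyl carbon is a double-bonded chain carbon, whereas in compound 3 it is a saturated chain carbon, so this is the same kind of change, not the same change. The step from compound 1 to compound 4 is expected to be a step that the limit leaves unreadable from compound 1 to compound 4, set beside an at least 2.4-fold higher number from compound 2 to compound 3 (0.38 log units; beyond the scatter), since the earlier step points toward a higher number and compound 1 already stands at a limit. The estimate for compound 4 is 120000 nM, between 50000 nM and 400000 nM, and is expected most likely to be reported only as a limit.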

Compound 4, half-maximal inhibitory concentration: > 50000 nM
Compound 4: only a limit was reported; the forecaster's own chance of this, stated with the estimate: 90%; the middle value is on the limit's open side.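

In this assay compound 4 gives > 50000 nM as a limit. Compound 1 also stands at a limit there, so no step between compound 1 and compound 4 can be read: the limit of > 50000 nM in this assay, at which 3 of the 4 values shown sit.

The compounds shown leave open whether 2,6-dimethylmorpholin-4-yl in place of methylamino on a carbonyl carbon changes the number at all when that carbon's other neighbour is a double-bonded chain carbon.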